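Swapping anilino for methylpiperazinyl on a shared purine-like core

A few compounds are considered here, and "the series" means these few. Any claim that something is new, unique, unknown or untested is made for them only; others in the source may bear on it.

Measured compounds:
- compound 1, `CC1CCN(c2nc(Cl)nc3c2ncn3Cc2ccc(/C=C/C(=O)Nc3ccccc3N)cc2)CC1`: 4.24%
- compound 2, `Nc1ccccc1NC(=O)c1ccc(Cn2cnc3c(Nc4ccccc4)nc(Cl)nc32)cc1`: 71.4%

Among the compounds with values here, in a functional assay on HCT-116 cells (Homo sapiens) for antiproliferative activity, read by CCK-8 assay, with a stated time of 72 h, tested at 2 uM (on this read-out higher numbers stand for a stronger effect at the one concentration tested and lower numbers for a weaker effect), compound 2 gives the higher of the two numbers, with compound 1 the only other value and far lower, a gap well beyond the scatter. The two compounds differ in more than one place, so their values are noted side by side without drawing a step between them.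

Compound 3, `CN1CCN(c2nc(Cl)nc3c2ncn3Cc2ccc(C(=O)Nc3ccccc3N)cc2)CC1`, keeps the core and the benzamide side of compound 2 and changes one group: 4-methylpiperazin-1-yl in place of anilino on an aromatic carbon. Within the data shown here, no measured pair shows this exact change. Compound 1, which also carries a saturated ring amine at that position, gave a low value, though with a different linker. A downward step, beyond the scatter, is expected for a number 31.4 percentage points lower from compound 2 to compound 3 (beyond the scatter). Compound 3 is estimated at 40%, with a range from 10% to 70%.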

Compound 3, a percentage reported as inhibition, at one concentration (the size of the read-out at that concentration, not a potency): 71.6%
Estimate against measurement, compound 3: 31.6 percentage points below; the measured number lies above the stated range.
By their numbers in this assay, from the lowest: compound 1; then compounds 2 and 3 (each within the scatter of the next).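

In this assay, putting 4-methylpiperazin-1-yl in place of anilino gives a number 0.2 percentage points higher from compound 2 to compound 3 (within the scatter) and so, at the one concentration tested, the two groups cannot be told apart at this position. Here a six-membered aromatic ring of carbon only and a non-aromatic ring with 2 hetero atoms serve alike, and the hydrogen-bond donor of anilino is not needed for this reading in this pair. No measurement at hand gives a reason for this match.

Compound 1 differs from compound 2 and from compound 3 in more than one place, so its low value cannot be pinned on either its ring amine or its linker. On these data alone, whether a morpholine ring or a plain amino group at this position would read the same remains open, as does whether compound 2 and compound 3 match across a range of concentrations.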